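Compound 3: pyrrolidin-1-yl in place of dimethylamino

The compounds below may be only part of what the source reports. "The series", "measured", "known", "first", "only" and "open" are said of these compounds alone.

In an ADME assay for permeability, using PAMPA, at pH 7.4 (a lower number here means that the compound crosses the layer more slowly, a higher number that the compound crosses the layer faster), compound 1 (`CN(C)c1ccccc1S(=O)(=O)Nc1ccc(-c2cccc(Cl)c2)nn1`) gives 35.7 10^-6 cm/s and compound 2 (`Cc1ccc(S(=O)(=O)Nc2ccc(-c3ccccc3N(C)C)nn2)cc1`) gives 35.7 10^-6 cm/s at the digits shown. Compound 2 therefore stands level with compound 1, within the scatter. Going by the values given here, the two compounds differ in more than one place, so their values give no single-change step to read across.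

Compound 3 (`Cc1ccc(S(=O)(=O)Nc2ccc(-c3ccccc3N3CCCC3)nn2)cc1`) carries pyrrolidin-1-yl in place of dimethylamino on an aromatic carbon of compound 2, at a position on a six-membered aromatic ring of carbon only, ortho to a large group (pyrrolidin-1-yl in place of dimethylamino on an aromatic carbon). Among the compounds with values here, no measured pair in this small set shows this change or any other single change, so the expectation has little support. In this assay no step beyond the scatter is expected, and neither direction is favoured. The expected move is small, as the estimated 1.0-fold higher number from compound 2 to compound 3 (0.00 log units; within the scatter) shows, and the estimate starts from compound 2 at 35.7 10^-6 cm/s as its only close reference. For compound 3 the estimated value is 36 10^-6 cm/s (expected range 20 10^-6 cm/s to 55 10^-6 cm/s).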

Compound 3, apparent permeability: 43.5 10^-6 cm/s
Beside the measured number, compound 3's estimate is 1.2-fold (0.08 log units) below it, and the stated range covers the measured number.
By their numbers in this assay, from the lowest: compounds 1, 2 and 3 (each within the scatter of the next).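

The series now holds its first step that can be read as a single change: in this assay pyrrolidin-1-yl in place of dimethylamino on an aromatic carbon, ortho to a large group, comes with a 1.2-fold higher number from compound 2 to compound 3 (0.09 log units; within the scatter) on a six-membered aromatic ring of carbon only. This place on the ring can therefore carry pyrrolidin-1-yl, with 5 heavy atoms and one five-membered non-aromatic ring, where dimethylamino had 3 heavy atoms and no ring, and the read-out stays within the scatter. No measurement at hand explains this result.

This one pair leaves open whether the same read-out holds at this place for morpholin-4-yl, which adds an oxygen to the ring, or for a group of another kind, such as a carboxylic acid or a primary amine. It also leaves open whether pyrrolidin-1-yl in place of dimethylamino gives a step within the scatter when the rest of the molecule differs, as it does in compound 1, where dimethylamino stands on the other aromatic ring of the molecule.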